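Adding an acetyl group to compound 2

The source may hold more compounds than are shown below. What is called first, only, known or untested is meant among the compounds shown, and "the series" means these compounds.

Of the compounds shown here, three built on a shared core have been tested in a functional assay on K562 cells (Homo sapiens), read by XTT assay, with a stated time of 48 h; on this read-out lower numbers stand for stronger inhibition and higher numbers for weaker inhibition. For compound 1 `CCCCCCCC#Cc1c(C(=O)OC)nnn1[C@@H]1O[C@H](CO)[C@H]2OC(C)(C)O[C@H]21` the result is a limit, > 10000 nM, and not a number. Compound 2 `COC(=O)C#Cc1c(C(=O)OC)nnn1[C@@H]1O[C@H](CO)[C@@H](OC(C)C)[C@H]1OC(C)C` gives 1450 nM, the higher of the two actual numbers. Compound 3 `CCOC(=O)C#Cc1c(C(=O)OCC)nnn1[C@@H]1O[C@H](COC(C)=O)[C@@H](OC(C)C)[C@H]1OC(C)C` gives 500 nM, a lower number than that of compound 2, and the gap lies beyond the usual scatter.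

Compound 4 `COC(=O)C#Cc1c(C(=O)OC)nnn1[C@@H]1O[C@H](COC(C)=O)[C@@H](OC(C)C)[C@H]1OC(C)C` has not yet been measured. It differs from compound 2 in one place: acetyl in place of hydrogen on an oxygen on a saturated carbon. In words, this is acetyl in place of hydrogen on an oxygen on a saturated carbon, turning hydroxymethyl into acetoxymethyl.

Among the compounds with values here, no measured pair shows this change alone. Compound 3 also carries acetoxymethyl, but it differs from compound 2 elsewhere too, so it is only a loose guide. With compound 3 at 500 nM, the expectation leans toward stronger inhibition rather than weaker. The expected change a 2.1-fold lower number from compound 2 to compound 4 (0.32 log units; beyond the scatter) is a modest one in this assay, and it may not clear the scatter by much. For compound 4 the estimated value is 700 nM, with an expected range from 280 nM to 1600 nM.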

Compound 4, half-maximal inhibitory concentration: 150 nM
Beside the measured number, compound 4's estimate is 4.7-fold (0.67 log units) above it; measured number outside the range, below it.
By their numbers in this assay, from the lowest: compound 4; then compound 3; then compound 2. At a limit, above all of these: compound 1.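

In this assay, within the data shown here, turning hydroxymethyl into acetoxymethyl gives a 9.7-fold lower number from compound 2 to compound 4 (0.99 log units; beyond the scatter) and so provides the first reading of this change on its own. Compound 3 also carries acetoxymethyl but differs elsewhere too, so it could only hint at the direction, whereas this pair shows that this oxygen on a saturated carbon need not carry a free hydrogen for inhibition in these cells, and that capping it with acetyl alone can move the number well beyond the scatter. Nothing shown here gives a measured reason for the size of this step.

Going by these compounds, this is a single pair on one set of side groups, so it remains open whether the same change would have a similar effect with other groups elsewhere on the shared core. On these data alone, it is also open whether acetyl itself matters or whether other groups on this oxygen, such as a methyl ether, a longer propanoyl ester or a benzoyl ester, would give a similar number, and what an amine in place of the hydroxy would do.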